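The source may report more compounds than this note shows. Statements on the series, on what has been measured and on what is new or still open speak of the compounds shown alone.

In a functional assay on HeLa cells (Homo sapiens) for inhibition (a higher number here means a weaker inhibitor of growth, a lower number a stronger inhibitor of growth), compound 2 (`O=C(OCc1ccccc1)c1ccsc1NC(=O)[C@@H]1CCCN1`) gives > 250 ug/mL as a limit of the assay, not a number. Compound 1 (`COC(=O)c1ccsc1NC(=O)[C@@H]1CCCN1`) gives > 250 ug/mL and this too is only a limit. Within the data shown here, the only measured step is a step that the two limits leave unreadable from compound 1 to compound 2 and it offers no size to carry over. Compound 3 (`CCOC(=O)c1ccsc1NC(=O)[C@@H]1CCCN1`) differs from compound 2 by methyl in place of phenyl on a saturated chain carbon bound to an oxygen next to a carbonyl group and so has ethyl in place of benzyl. Compound 1 and compound 2 share the limit of > 250 ug/mL in this assay, at which 2 of the 2 values shown sit, and so no change beyond the scatter is expected. The expected step is a step that the limit leaves unreadable from compound 2 to compound 3 in this estimate. Compound 3 is estimated at 300 ug/mL with a range of 150 ug/mL to 600 ug/mL and will probably be reported only as a limit.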

Compound 3, concentration for 50% growth inhibition: 35.3 ug/mL
For compound 3 the middle estimate is 8.5-fold (0.93 log units) above the measured one, outside the stated range (below it).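

In this assay, methyl in place of phenyl on a saturated chain carbon bound to an oxygen next to a carbonyl group gives an at least 7.0-fold lower number from compound 2 to compound 3 (0.85 log units; beyond the scatter), and methyl in place of hydrogen at the same place gives an at least 7.0-fold lower number from compound 1 to compound 3 (0.85 log units; beyond the scatter). This shows that the place can change growth inhibition, which the first two compounds could not show, and that ethyl gives a readable number here while the larger benzyl and smaller methyl do not. Each step gives only a smallest size, not a full one, because the other two compounds sit at a limit of the assay: the limit of > 250 ug/mL in this assay, at which 2 of the 3 values shown sit.

Going by these compounds, whether a propyl group or a longer chain would lower the number further remains open. So does what an amine or a carboxylic acid at the end of the chain would do.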